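From Methoxycarbonyl to Ethoxycarbonyl on a Shared Core

The compounds below may be only part of what the source reports. "The series", "measured", "known", "first", "only" and "open" are said of these compounds alone.

In a functional assay on SK-MEL-28 cells (Homo sapiens) for inhibition, read by MTT assay, with a stated time of 72 h (on this read-out lower numbers stand for stronger inhibition of growth and higher numbers for weaker inhibition of growth), compound 1 `CC1(C)CCC[C@]2(C)[C@@H](C=O)C(C=O)=CC[C@@H]12` gives 65000 nM, while compound 2 `COC(=O)/C=C/C1=CC[C@H]2C(C)(C)CCC[C@]2(C)[C@H]1C=O` gives 27000 nM. Among the compounds with values here, compound 2 thus holds the lower of the two numbers measured so far, and compound 1 is its only neighbour.

Compound 3 `CCOC(=O)/C=C/C1=CC[C@H]2C(C)(C)CCC[C@]2(C)[C@H]1C=O` keeps everything in compound 2 except the ester. The change is methyl in place of hydrogen on a saturated chain carbon bound to an oxygen next to a carbonyl group, so methoxycarbonyl becomes ethoxycarbonyl.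

Within the data shown here, no measured step covers this exact change. Among the measured compounds shown here, the only step that bears on it, a 2.4-fold lower number from compound 1 to compound 2 (0.38 log units; beyond the scatter), put 2-(methoxycarbonyl)ethenyl in place of formyl and was modest, though beyond the scatter. That exchange was much larger than the addition of one methyl, so no step beyond the scatter is expected in this assay. The estimated change is a 1.1-fold lower number from compound 2 to compound 3 (0.03 log units; within the scatter), in no firm direction. Compound 3 is estimated at 25000 nM, with an expected range of 13000 nM to 50000 nM.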

Compound 3, concentration for 50% growth inhibition: 29000 nM
Beside the measured number, compound 3's estimate is 1.2-fold (0.06 log units) below it; the range from low to high includes it.
By their numbers in this assay, from the lowest: compounds 2 and 3 (each within the scatter of the next); then compound 1.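

In this assay, within the data shown here, the step of a 1.1-fold higher number from compound 2 to compound 3 (0.03 log units; within the scatter) shows for the first time that methyl in place of hydrogen at this saturated chain carbon can be read directly, and methoxycarbonyl and ethoxycarbonyl cannot be told apart on this read-out. The step of a 2.2-fold lower number from compound 1 to compound 3 (0.35 log units; beyond the scatter) is modest but beyond the scatter, so the ethyl ester repeats what the methyl ester showed in the step of a 2.4-fold lower number from compound 1 to compound 2 (0.38 log units; beyond the scatter), and the separation from compound 1 does not depend on which of these two esters is present. Nothing measured here gives a reason for either result, and no supporting evidence bears on this ester change.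

The compounds shown leave open whether a longer chain such as propyl or butyl on the ester oxygen, or a free carboxylic acid or an amide in place of the ester, would move the number beyond the scatter. They also leave open what happens when the formyl group that compound 2 and compound 3 keep on the shared core is replaced by a primary alcohol or a nitrile.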